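The source may report more compounds than this note shows. Statements on the series, on what has been measured and on what is new or still open speak of the compounds shown alone.

In a physicochemical assay for lipophilicity, read by HPLC (a higher number here means a more lipophilic compound, a lower number a more polar compound), compound 2 `Cc1ccsc1C(=CCCN(C)C(CCO)C(=O)NCc1ccc(Cl)cc1)c1sccc1C` gives 6.38 and compound 1 `Cc1ccc(CNC(=O)C(CC(C)O)N(C)CCC=C(c2sccc2C)c2sccc2C)cc1` with its 4-methylbenzyl group gives 6.15 which lies within the usual scatter of the other value. Compound 3 `Cc1ccc(CNC(=O)C(CCO)N(C)CCC=C(c2sccc2C)c2sccc2C)cc1` is still unmeasured and differs from compound 2 in one place, with methyl in place of chloro on an aromatic carbon and the rest unchanged. Within the data shown here, no measured pair shows this swap alone, so only a small change is expected. The estimated move a number 0.18 log units lower from compound 2 to compound 3 (within the scatter) is slightly downward and stays within the scatter. In this assay compound 3 is expected at 6.2 with an estimated range from 5.9 to 6.5 once measured.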

Compound 3, partition coefficient: 6.2
Compound 3: the middle estimate sits on the measured number at the digits printed; measured number inside the range.
By their numbers in this assay, from the lowest: compounds 1, 3 and 2 (each within the scatter of the next).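

With 4-methylbenzyl in place of 4-chlorobenzyl, this assay gives a number 0.18 log units lower from compound 2 to compound 3 (within the scatter), so on this aromatic carbon the two groups cannot be told apart by this measurement. Hydrogen in place of methyl on the saturated chain carbon bound to an oxygen gives a number 0.05 log units higher from compound 1 to compound 3 (within the scatter), so that change also stays inside the noise. Nothing measured here offers an explanation for either step. On these data alone, whether an amine or a carboxylic acid in place of chloro on the ring, or a longer chain in place of that chain methyl, would give a step beyond the scatter remains open.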